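The source may report more compounds than this note shows. Statements on the series, on what has been measured and on what is new or still open speak of the compounds shown alone.

Measured in a functional assay on A 172 cells (Homo sapiens) for cytotoxicity, read by colorimetric assay and MTT assay (on this read-out lower numbers stand for stronger inhibition and higher numbers for weaker inhibition), as follows
compound 1 `CCOC(=O)Cn1c(=O)c(-c2ccc(OC)cc2)cc2c(OC)cc(OC)cc21` gives 10000 nM as its value
compound 2 `COc1ccc(-c2cc3c(OC)cc(OC)cc3n(CCCC#N)c2=O)cc1` gives 10000 nM as its value
compound 3 `COc1ccc(-c2cc3c(OC)cc(OC)cc3n(CC(=O)OCc3ccccc3)c2=O)cc1` gives 10000 nM as its value

Compound 3 stands level with compounds 1 and 2 at the digits shown, so the numbers do not separate the three. The next compound is compound 4 `COc1ccc(-c2cc3c(OC)cc(OC)cc3n(CC(=O)O)c2=O)cc1`, which carries hydrogen in place of benzyl on an oxygen next to a carbonyl group, that is, benzyloxycarbonyl to carboxy. The closest measured step alters the same group and reads no change at the digits printed from compound 1 to compound 3 (within the scatter) while the two steps that exchange the group on the chain read no change at the digits printed from compound 1 to compound 2 (within the scatter) and no change at the digits printed from compound 2 to compound 3 (within the scatter) so none of the three goes beyond the scatter. Among the measured compounds shown here, no measured compound carries a carboxy group, which leaves this change outside what those steps cover. In this assay the expected result is no change at the digits printed from compound 3 to compound 4 (within the scatter) with neither direction favoured. For compound 4 the estimated value is 10000 nM with an expected range of 5000 nM to 20000 nM on this read-out.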

Compound 4, half-maximal inhibitory concentration: 10000 nM
For compound 4 middle estimate and measured number coincide at the digits printed, within the range that was stated.
By their numbers in this assay, from the lowest: compounds 1, 2, 3 and 4 (each within the scatter of the next).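

In this assay, taking the benzyl off the oxygen next to a carbonyl group, so that benzyloxycarbonyl becomes carboxy, gives no change at the digits printed from compound 3 to compound 4 (within the scatter). The same holds for the carboxy group against the other two side chains, with no change at the digits printed from compound 2 to compound 4 (within the scatter) and no change at the digits printed from compound 1 to compound 4 (within the scatter), so a hydrogen on this oxygen reads level with ethyl and benzyl, and a free carboxy group separates nothing on this read-out. No supporting evidence bears on this result.

All four compounds share the core and read level, so the compounds shown do not tell whether any group on this chain can move the value. As far as these compounds go, an amine or an amide on the same chain, a longer chain ending in a carboxylic acid, and changes to the shared core all remain open.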